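The compounds below may be only part of what the source reports. "The series", "measured", "known", "first", "only" and "open" are said of these compounds alone.

Measured so far:
compound 1 `CCCCC[C@@H](CCC[C@H]1CC=CC(=O)O1)OC` — 20600 nM
compound 2 `CCCCC[C@H](C[C@@H](O)C[C@@H]1CC=CC(=O)O1)OC` — 54500 nM

Both were read in a functional assay on A2780 cells (Homo sapiens) for cytotoxicity, read by MTT assay, with a stated time of 24 h; on this read-out higher numbers stand for weaker inhibition and lower numbers for stronger inhibition. Compound 2 gives the higher of the two numbers, and compound 1 gives the lower one.

Compound 3 `CCCCC[C@H](CCC[C@@H]1CC=CC(=O)O1)OC` is not yet measured. Against compound 2 it carries the change (hydrogen in place of hydroxy on a saturated chain carbon bound to two saturated chain carbons). Among the measured compounds shown here, no measured pair tells the size of this change, so the expectation rests on compound 1, whose value is 20600 nM; compound 3 shares its skeleton. Compound 3 is expected to come in near that, a modest step downward from compound 2 of a 2.2-fold lower number from compound 2 to compound 3 (0.34 log units; beyond the scatter), close to the scatter. The estimate for compound 3 is 25000 nM, with a range of 10000 nM to 60000 nM.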

Compound 3, half-maximal inhibitory concentration: 14400 nM
The estimate for compound 3 lay 1.7-fold (0.24 log units) above the measured number, and the stated range covers the measured number.
By their numbers in this assay, from the lowest: compounds 3 and 1 (each within the scatter of the next); then compound 2.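

In this assay, hydrogen in place of hydroxy on a saturated chain carbon bound to two saturated chain carbons gives a 3.8-fold lower number from compound 2 to compound 3 (0.58 log units; beyond the scatter), so on this skeleton the hydroxy goes with the higher number. The mirror-image pair gives a 1.4-fold lower number from compound 1 to compound 3 (0.16 log units; within the scatter), so this read-out does not separate the two forms, a reading that rests on a single pair: the fact that compounds 1 and 3 differ only in the configuration as drawn.

From the compounds shown here alone, whether an amine or a carboxylic acid on this carbon would read like the hydroxy remains open. So does the effect of a longer chain.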